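The source may report more compounds than this note shows. Statements on the series, on what has been measured and on what is new or still open speak of the compounds shown alone.

In an ADME assay on BJ cells (Homo sapiens) for cytotoxicity, read by luminescence, with a stated time of 72 h (a lower number here means that less compound is needed, a higher number that more compound is needed for the effect), compound 1 `C=Cc1cccc(-c2[nH]c3cc(OC)ccc3c(=O)c2C(=O)OCC)c1` gives only a limit of > 21500 nM. Compound 2 `CCOC(=O)c1c(-c2cccc(C(F)(F)F)c2)[nH]c2cc(OC)ccc2c1=O` gives only a limit of > 21500 nM as well. The step that the two limits leave unreadable from compound 1 to compound 2 cannot be read, since both values sit at the limit (the limit of > 21500 nM in this assay, at which 2 of the 2 values shown sit). Compound 2 thus stands at the limit itself, with no number to place it. Compound 3 `CCOC(=O)c1c(-c2cccc([N+](=O)[O-])c2)[nH]c2cc(OC)ccc2c1=O` differs from compound 2 by nitro in place of trifluoromethyl on an aromatic carbon. Among the measured compounds shown here, no measured step bears on this change; the one comparison available ends in two limits. Compound 3 is therefore expected to stay around the limit, estimated at 30000 nM with a range of 15000 nM to 60000 nM, the step that the limit leaves unreadable from compound 2 to compound 3 expected to be no larger than the scatter.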

Compound 3, half-maximal effective concentration: > 21500 nM
Compound 3: no number, only a limit; the forecaster's own chance of this, stated with the estimate: 85%; the middle value does not contradict the limit.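

Among the compounds shown here, compound 1, compound 2 and compound 3 each give only a limit, so no step among them can be read: the limit of > 21500 nM in this assay, at which 3 of the 3 values shown sit. The compounds shown leave open whether exchanging vinyl, trifluoromethyl and nitro changes the response in this assay.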